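The source may hold more compounds than are shown below. What is called first, only, known or untested is meant among the compounds shown, and "the series" means these compounds.

Measured so far:
compound 1 `O=C(Nc1cccc(-n2cc(-c3ccncc3)c(-c3ccc(Cl)c(O)c3)n2)c1)Nc1cccc(C(F)(F)F)c1` gives 1910 nM
compound 2 `COc1cc(-c2nn(-c3cccc(NC(=O)c4cccc(C(F)(F)F)c4)c3)cc2-c2ccncc2)ccc1Cl` gives 2460 nM

In a functional assay on SNB-19 cells (Homo sapiens) for inhibition, read by sulforhodamine B assay, with a stated time of 48 h (on this read-out lower numbers stand for stronger inhibition of growth and higher numbers for weaker inhibition of growth), compound 2 gives 2460 nM, the higher of the two numbers measured, yet its gap to compound 1 lies within the scatter, so the two compounds cannot be told apart on these data. Compound 3 `COc1cc(-c2nn(-c3cccc(NC(=O)c4ccc(Cl)c(C(F)(F)F)c4)c3)cc2-c2ccncc2)ccc1Cl` is not yet measured. It differs from compound 2 by chloro in place of hydrogen on an aromatic carbon, on the amide-bearing ring, ortho to the trifluoromethyl group. Among the compounds with values here, no measured pair shows this change, so nothing here says how large its effect should be. The step from compound 2 to compound 3 is expected to be small, a 1.4-fold lower number from compound 2 to compound 3 (0.14 log units; within the scatter), not clearly beyond the scatter. Compound 3 is estimated at 1800 nM, within a range from 600 nM to 5000 nM.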

Compound 3, concentration for 50% growth inhibition: 8680 nM
For compound 3 the middle estimate is 4.8-fold (0.68 log units) below the measured one, outside the stated range (above it).
By their numbers in this assay, from the lowest: compounds 1 and 2 (each within the scatter of the next); then compound 3.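

In this assay chloro in place of hydrogen on the 3-(trifluoromethyl)phenyl group, ortho to the trifluoromethyl group, gives a 3.5-fold higher number from compound 2 to compound 3 (0.55 log units; beyond the scatter) and so weakens growth inhibition. Within the data shown here, this is the first change measured on this ring, and it shows that one added chlorine atom at this position is enough to move the result beyond the scatter. No measured information here accounts for the loss. On these data alone, whether fluoro, methyl or an amine at the same position would cost as much remains open. So does whether chloro would have the same effect on compound 1.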